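The compounds below may be only part of what the source reports. "The series", "measured", "known", "first", "only" and "open" are said of these compounds alone.

Compound 1 `Oc1ccc(-c2cc(-c3ccccn3)nc(-c3ccccc3Cl)c2)cc1` gives 5.2% in an assay on isolated protein for inhibition of DNA topoisomerase 1 (Homo sapiens), with a stated time of 30 min, tested at 100 uM; on this read-out lower numbers stand for a weaker effect and higher numbers for a stronger effect at the one concentration tested.
Compound 2 `Oc1ccc(-c2cc(-c3ccco3)nc(-c3ccccc3Cl)c2)cc1` gives 3.9% in this assay.
Compound 3 `Oc1ccc(-c2cc(-c3ccc(Cl)cc3)nc(-c3ccccn3)c2)cc1` gives 12.7% in this assay.

Compound 1 and compound 3 share the same atoms joined differently: 4-chlorophenyl in place of 2-chlorophenyl on an aromatic carbon. This rearrangement gives a number 7.5 percentage points higher from compound 1 to compound 3 (within the scatter). The change from compound 1 to compound 2 is furan-2-yl in place of pyridin-2-yl on an aromatic carbon, and it gives a number 1.3 percentage points lower from compound 1 to compound 2 (within the scatter). Compound 4 `Oc1ccc(-c2cc(-c3ccc(Cl)cc3)nc(-c3ccco3)c2)cc1` has not been measured; it differs from compound 3 by furan-2-yl in place of pyridin-2-yl on an aromatic carbon. This is the same kind of change as that from compound 1 to compound 2, but the surroundings differ: the place is meta to a 4-chlorophenyl group in compound 3, where in compound 1 it was meta to a 2-chlorophenyl group. Compound 4 is expected to show a step of a number 1.7 percentage points lower from compound 3 to compound 4 (within the scatter), because the earlier step of a number 1.3 percentage points lower from compound 1 to compound 2 (within the scatter) was within the scatter. Compound 4 is therefore estimated at 11%, expected between 3% and 20% in this assay.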

Compound 4, a percentage reported as inhibition, at one concentration (the size of the read-out at that concentration, not a potency): 15.8%
For compound 4 the middle estimate is 4.8 percentage points below the measured one, within the range that was stated.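

Furan-2-yl in place of pyridin-2-yl gives a number 3.1 percentage points higher from compound 3 to compound 4 (within the scatter), and the change carries from one core to the other with no detectable difference: the same change on two cores in this assay, a number 1.3 percentage points lower (within the scatter) from compound 1 to compound 2 and a number 3.1 percentage points higher (within the scatter) from compound 3 to compound 4, 4.4 percentage points apart, within the scatter of two such steps. Going by these compounds alone, likewise, 4-chlorophenyl in place of 2-chlorophenyl gives a number 11.9 percentage points higher from compound 2 to compound 4 (beyond the scatter), which agrees with its earlier step even though only this step lies beyond the scatter: the same change on two cores in this assay, a number 7.5 percentage points higher (within the scatter) from compound 1 to compound 3 and a number 11.9 percentage points higher (beyond the scatter) from compound 2 to compound 4, 4.4 percentage points apart, within the scatter of two such steps. Both changes thus carry over between the cores compared here, but this rests on just two pairs for each change and does not show that either change would behave the same way on any other core.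

From the compounds shown here alone, it remains open how the read-out would respond if an amine or a carboxylic acid took the place of the chlorine or of the hydroxyl of the 4-hydroxyphenyl group.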